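From methoxy to benzyloxy on a shared core

The compounds below may be only part of what the source reports. "The series", "measured", "known", "first", "only" and "open" are said of these compounds alone.

Measured in an ADME assay on L6 cells (Rattus norvegicus) for cytotoxicity, read by resazurin assay, with a stated time of 72 h; a higher number here means a weaker inhibitor, a lower number a stronger inhibitor:
- compound 1 `CC(C)c1ccc(C(=O)NC(=O)c2ccccc2O)cc1`: 19 ug/mL
- compound 2 `N#Cc1ccc(C(=O)NC(=O)c2ccccc2O)cc1`: 55 ug/mL
- compound 3 `COc1ccc(C(=O)NC(=O)c2ccccc2O)cc1`: 39 ug/mL

Compound 3 sits among the higher numbers. The step of a 1.4-fold lower number from compound 2 to compound 3 (0.15 log units; within the scatter) is no real change, while a 2.1-fold higher number from compound 1 to compound 3 (0.31 log units; beyond the scatter) is modest, and a 2.9-fold higher number from compound 1 to compound 2 (0.46 log units; beyond the scatter) is similar in size. Compound 4 `O=C(NC(=O)c1ccccc1O)c1ccc(OCc2ccccc2)cc1` turns methoxy into benzyloxy: phenyl in place of hydrogen on a saturated chain carbon bound to an oxygen on an aromatic ring. Within the data shown here, no measured step adds a phenyl, so the guidance is indirect. Among the measured compounds shown here, the entering group is carbon only, as is the isopropyl of compound 1 at 19 ug/mL, the lowest number so far. A modest step towards a lower number is therefore expected in this assay. For compound 4 the estimated value is 16 ug/mL, with an expected range of 6 ug/mL to 40 ug/mL. That estimate means an expected 2.4-fold lower number from compound 3 to compound 4 (0.39 log units; beyond the scatter).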

Compound 4, half-maximal inhibitory concentration: 64 ug/mL
Compound 4: the middle estimate sits 4.0-fold (0.60 log units) below what was measured; measured number outside the range, above it.
By their numbers in this assay, from the lowest: compound 1; then compounds 3, 2 and 4 (each within the scatter of the next).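

In this assay the step of a 1.6-fold higher number from compound 3 to compound 4 (0.22 log units; within the scatter) is no real change, so a phenyl on this saturated chain carbon leaves the number where it was. Benzyloxy also reads level with the nitrile of compound 2, with a 1.2-fold higher number from compound 2 to compound 4 (0.07 log units; within the scatter) inside the scatter, and only isopropyl stands apart, with a 3.4-fold higher number from compound 1 to compound 4 (0.53 log units; beyond the scatter) as a modest step. Nothing available offers a reason for this result. Still open, as far as these compounds go, is how an amine or a carboxylic acid in this place would read, or a longer chain ending in the same phenyl.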